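A few compounds are considered here, and "the series" means these few. Any claim that something is new, unique, unknown or untested is made for them only; others in the source may bear on it.

Working notes on the series.

Of the compounds shown here, three of the shared core have been measured. Compound 1 `COc1ccc2ncc(S(=O)(=O)c3ccc(Cl)c(Cl)c3)c(N3CCC(C)CC3)c2c1` gives 87% in an assay on isolated protein for displacement of a labelled ligand from metabotropic glutamate receptor 5 (Homo sapiens), with a stated time of 60 min, tested at 1 uM; on this read-out higher numbers stand for more inhibition at the one concentration tested (going by the name of the read-out) and lower numbers for less inhibition. Compound 2 `Cc1ccc(S(=O)(=O)c2cnc3ccc(F)cc3c2N2CCC(C)CC2)cc1C` gives 92% in this assay. Compound 3 `CC1CCN(c2c(S(=O)(=O)c3ccc(F)cc3)cnc3ccc(F)cc23)CC1` gives 87% in this assay, a value that stands level with compound 1 at the digits shown and is separated from compound 2 only by the step of a number 5 percentage points lower from compound 2 to compound 3 (within the scatter), which lies within the scatter. All three numbers sit within the scatter of one another, so no order among them can be stated.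

The next compound, compound 4 `CC1CCN(c2c(S(=O)(=O)c3ccc(Cl)c(Cl)c3)cnc3ccc(F)cc23)CC1`, is to be measured in this assay. It differs from compound 3 in one place: 3,4-dichlorophenyl in place of 4-fluorophenyl on a sulfonyl sulfur. Going by the values given here, the one measured step that touches the group on the sulfonyl sulfur, a number 5 percentage points lower from compound 2 to compound 3 (within the scatter), was within the scatter. Compound 1 also carries 3,4-dichlorophenyl on the sulfonyl sulfur, but it differs from compound 3 in a second place as well, so only its value can be noted. On this basis the expected step of a number 1 percentage points higher from compound 3 to compound 4 (within the scatter) is none beyond the scatter. Compound 4 is therefore estimated at 88% in this assay, within the range 78% to 96%.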

Compound 4, a percentage reported as inhibition, at one concentration (the size of the read-out at that concentration, not a potency): 91%
Compound 4: middle estimate off by 3 percentage points, on the low side, and the stated range covers the measured number.
By their numbers in this assay, from the lowest: compounds 1, 3, 4 and 2 (each within the scatter of the next).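

Three aryl groups on the sulfonyl sulfur can now be compared on one core, and the steps of a number 4 percentage points higher from compound 3 to compound 4 (within the scatter) and a number 1 percentage points lower from compound 2 to compound 4 (within the scatter) show that 4-fluorophenyl, 3,4-dichlorophenyl and 3,4-dimethylphenyl cannot be told apart in this assay here. Going by these compounds alone, the step of a number 4 percentage points higher from compound 1 to compound 4 (within the scatter) is the first reading of a change away from the sulfonyl sulfur, fluoro in place of methoxy on an aromatic carbon, and it too gives no separable difference. No independent measurement bears on these results.

From the compounds shown here alone, whether an amine or a carboxylic acid on that aryl group, or a plain methyl in its place on the sulfonyl sulfur, would move the number beyond the scatter stays open. A reading at one concentration also gives no potency, so any difference in potency among these compounds remains unknown.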